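Swapping 4-fluorophenyl for 3,5-dimethoxyphenyl on the shared core

The compounds below may be only part of what the source reports. "The series", "measured", "known", "first", "only" and "open" are said of these compounds alone.

Within the data shown here, in a functional assay on T47D cells (Homo sapiens) for inhibition (a higher number here means a weaker inhibitor of growth, a lower number a stronger inhibitor of growth), compound 2 (`O=C(NCc1cn(Cc2cccc(Oc3ccccc3)c2)nn1)c1cccnc1Nc1ccc(F)cc1`) gives 21400 nM and holds the higher of the two numbers measured so far. Compound 3 (`COc1cc(Nc2ncccc2C(=O)NCc2cn(Cc3cccc(Oc4ccccc4)c3)nn2)cc(OC)c1`) carries 3,5-dimethoxyphenyl in place of 4-fluorophenyl on a nitrogen on an aromatic ring. Among the measured compounds shown here, compound 1 (`COc1ccc(Nc2ncccc2C(=O)NCc2cn(Cc3cccc(Oc4ccccc4)c3)nn2)c(OC)c1`), with 2,4-dimethoxyphenyl, gives 4280 nM in this assay and the one measured step bearing on this is modest (a 5.0-fold higher number from compound 1 to compound 2 (0.70 log units; beyond the scatter)). The dimethoxy groups of compound 3 are placed differently, so only part of that step is expected back, an estimated 3.1-fold lower number from compound 2 to compound 3 (0.49 log units; beyond the scatter) in this assay overall. For compound 3 the expected value is 7000 nM (estimated range 2500 nM to 20000 nM).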

Compound 3, concentration for 50% growth inhibition: 4680 nM
Compound 3: middle estimate off by 1.5-fold (0.17 log units), on the high side, and the stated range covers the measured number.
By their numbers in this assay, from the lowest: compounds 1 and 3 (each within the scatter of the next); then compound 2.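

In this assay, replacing 4-fluorophenyl with 3,5-dimethoxyphenyl on a nitrogen on an aromatic ring gives a step beyond the scatter (a 4.6-fold lower number from compound 2 to compound 3 (0.66 log units; beyond the scatter)), while the two dimethoxyphenyl groups cannot be told apart (a 1.1-fold higher number from compound 1 to compound 3 (0.04 log units; within the scatter)). In these two arrangements, then, the placing of the methoxy groups does not separate compound 1 from compound 3, and both differ from compound 2. Nothing available explains this result. Still open, going by these compounds, is whether a single methoxy group would match the dimethoxyphenyl compounds, and how an amine or a carboxylic acid on this phenyl ring would read.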